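The source may hold more compounds than are shown below. What is called first, only, known or untested is meant among the compounds shown, and "the series" means these compounds.

Measured so far:
- compound 1, `Cc1cn2cc(-c3cc4ccc(N5CCN(C)CC5)cc4oc3=O)nc2c(C)n1`: 530 ng.h/mL
- compound 2, `Cc1cn2cc(-c3cc4ccc(N5CCN(C)CC5)cc4c(=O)o3)nc2cn1`: < 10 ng.h/mL

In an ADME assay on the whole organism (Rattus norvegicus, strain Sprague-Dawley) for pharmacokinetics, with a stated time of 6 h, at a dose of 10 mg/kg by the oral route (a lower number here means less compound in the circulation, a higher number more compound in the circulation at the dose given), compound 1 gives 530 ng.h/mL. Compound 2 gives only < 10 ng.h/mL, which is a limit of the assay and not a number, the value sitting at the limit of < 10 ng.h/mL in this assay, at which 1 of the 2 values shown sits. Within the data shown here, compound 1 is therefore the only compound here with an actual number in this assay; compound 1 and compound 2 differ in more than one place, so no single step between them is known, and the two values show only that one is a number and the other a limit.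

Compound 3, `Cc1cn2cc(-c3cc4ccc(N5CCN(C)[C@@H](C)C5)cc4oc3=O)nc2c(C)n1`, has not yet been measured in this assay. It differs from compound 1 by methyl in place of hydrogen on a saturated ring carbon. Among the measured compounds shown here, no measured step of this kind is available; the change is expected to stay within the usual scatter, with no clear direction. For compound 3 the expected step is a 1.1-fold higher number from compound 1 to compound 3 (0.05 log units; within the scatter). Compound 3 is expected to give 600 ng.h/mL, between 200 ng.h/mL and 1500 ng.h/mL.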

Compound 3, area under the concentration-time curve: 260 ng.h/mL
Beside the measured number, compound 3's estimate is 2.3-fold (0.36 log units) above it; low and high end bracket the measured number.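

Among these compounds, the change from 4-methylpiperazin-1-yl to 3,4-dimethylpiperazin-1-yl gives the first step between two compounds that differ in one place: in this assay it is a 2.0-fold lower number from compound 1 to compound 3 (0.31 log units; beyond the scatter). A single methyl on a saturated ring carbon, next to the ring nitrogen and next to the ring atom that bears a methyl group, is thus enough to move the number beyond the usual scatter, though only modestly, and this could not be read from the earlier pair, which differs in more than one place. Nothing shown here gives a cause for this step.

The compounds shown leave open whether an ethyl or a hydroxymethyl group on this ring carbon would take the number further down or bring it back up. They also leave open whether the opposite configuration at this carbon would give the same result as compound 3.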